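Trimming a Diethoxy Chain to a Hydroxyl Tail

The source may hold more compounds than are shown below. What is called first, only, known or untested is meant among the compounds shown, and "the series" means these compounds.

Of the compounds shown here, two have been measured in an assay on NK92 cells for inhibition of interleukin-2 (Homo sapiens), read by AlphaScreen, with stated times of 30 min and 1 h; on this read-out higher numbers stand for weaker inhibition and lower numbers for stronger inhibition. Compound 1 `Cn1c(Cc2nn(C)c(=O)c3ccccc23)nnc1SCCCCCCCC(=O)Nc1ccc(Cl)cc1Cl` gives 350 nM in this assay. Compound 2 `CCOC(CCn1c(Cc2nn(C)c(=O)c3ccccc23)nnc1SCC(=O)Nc1ccc(Cl)cc1Cl)OCC` reaches only a limit of the assay, > 30000 nM, and so no number for its potency is available. Going by the values given here, compound 2 therefore stands at the limit of > 30000 nM in this assay, at which 1 of the 2 values shown sits, while compound 1 is the only member with a measured value. Compound 3 `Cn1nc(Cc2nnc(SCC(=O)Nc3ccc(Cl)cc3Cl)n2CCCO)c2ccccc2c1=O` is the next member awaiting measurement, and it differs from compound 2 in one place: hydroxymethyl in place of diethoxymethyl on a saturated chain carbon, two bonds along the chain from an aromatic nitrogen. Since compound 2 gave only a limit, the size of this step cannot be anchored in a measured value, and the expectation for compound 3 is uncertain. From the compounds shown here alone, compound 3 is estimated to show an at least 2.0-fold lower number from compound 2 to compound 3 (0.30 log units; that floor lies within the scatter) in this assay, an expected gain whose extent remains open. The estimate for compound 3 is 15000 nM, with a range from 2000 nM to 60000 nM.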

Compound 3, half-maximal inhibitory concentration: > 30000 nM
Compound 3: no number, only a limit; the forecaster's own chance of this, stated with the estimate: 50%; middle value at least 2.0-fold (0.30 log units) from the limit.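

In this assay compound 3 reaches only a limit of the assay (> 30000 nM). Going by these compounds alone, compound 2 also stands at a limit, so no step between compound 2 and compound 3 can be read. The compounds shown leave open how much potency, if any, separates these two compounds.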